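Dimethylamino in place of methoxy: compound 3 to compound 4

A few compounds are considered here, and "the series" means these few. Any claim that something is new, unique, unknown or untested is made for them only; others in the source may bear on it.

Measured in a functional assay for inhibition, with Homo sapiens as the target; on this read-out lower numbers stand for stronger inhibition and higher numbers for weaker inhibition:
compound 1 `CN(C)c1ccc(Nc2nccc(-c3ccccn3)n2)cc1`: 3300 nM
compound 2 `Cc1cn(-c2ccc(Nc3nccc(-c4ccncc4)n3)cc2)cn1`: > 3000 nM, a limit and not a number
compound 3 `COc1ccc(Nc2nccc(-c3ccncc3)n2)cc1`: 4200 nM

Compound 3 stands at 4200 nM, within the scatter of compound 1. The next compound to read is compound 4 `CN(C)c1ccc(Nc2nccc(-c3ccncc3)n2)cc1`, with dimethylamino in place of methoxy on an aromatic carbon. Within the data shown here, the only measured step, a step that the limit leaves unreadable from compound 2 to compound 3, offers no size to carry over. Compound 1 also carries dimethylamino and gives 3300 nM, so no step beyond the scatter is expected in this assay. The expected step is a 1.2-fold lower number from compound 3 to compound 4 (0.08 log units; within the scatter). For compound 4 the estimated value is 3500 nM, with an expected range from 1300 nM to 8000 nM.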

Compound 4, half-maximal inhibitory concentration: 3700 nM
Compound 4: middle estimate off by 1.1-fold (0.02 log units), on the low side; the measured number falls inside the stated range.
By their numbers in this assay, from the lowest: compounds 1, 4 and 3 (each within the scatter of the next).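

In this assay, dimethylamino in place of methoxy on this aromatic carbon gives no change that can be told from the scatter: a 1.1-fold lower number from compound 3 to compound 4 (0.06 log units; within the scatter). With dimethylamino held constant, pyridin-4-yl in place of pyridin-2-yl also stays within the scatter: a 1.1-fold higher number from compound 1 to compound 4 (0.05 log units; within the scatter). The step from compound 2 to compound 4 cannot be read, as the value of compound 2 is a limit: the limit of > 3000 nM in this assay, at which 1 of the 4 values shown sits.

As far as these compounds go, whether a primary amine, a carboxylic acid or a longer alkoxy chain on this aromatic carbon would move the number beyond the scatter stays open. The same holds for pyridin-3-yl in place of pyridin-4-yl.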